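The source may report more compounds than this note shows. Statements on the series, on what has been measured and on what is new or still open speak of the compounds shown alone.

In an ADME assay on a cell-free system (plasma, Mus musculus) for metabolic stability, tested at 1 uM (on this read-out higher numbers stand for a longer-lived compound and lower numbers for a shorter-lived compound), compound 1 (`C=CC(=O)NC1CN(S(=O)(=O)c2ccc(NC(=O)OCc3ccccc3)cc2)C1`) gives > 6 h as its reading, which is a limit of the assay and not a number. Compound 2 (`C=CC(=O)NC1CCN(S(=O)(=O)c2ccc(C(=O)N(C)Cc3ccccc3)cc2)CC1`) gives > 6 h as its reading, and this too is only a limit. Compound 2 therefore has no exact half-life and stands on the limit of > 6 h in this assay, at which 2 of the 2 values shown sit, and nothing finer. Compound 3 (`C=CC(=O)NC1CCN(S(=O)(=O)c2ccc(C(=O)NC3CCCc4ccccc43)cc2)CC1`) carries (1,2,3,4-tetrahydronaphthalen-1-yl)amino in place of benzyl(methyl)amino on a carbonyl carbon. No measured pair sizes this change. Since compound 2 reads > 6 h as a limit, no shift beyond the usual scatter is expected in this assay, in either direction. The expected step that the limit leaves unreadable from compound 2 to compound 3 is accordingly small. For compound 3 the estimated half-life is 8 h within an expected range from 4 h to 16 h and the assay may well report only a limit.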

Compound 3, half-life: > 6 h
Compound 3: a limit, no number; the forecaster's own chance of this, stated with the estimate: 75%; the middle value is on the limit's open side.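

Compound 3 gives > 6 h, which is a limit and not a number, so no step can be read from compound 2 to compound 3 in this assay: the limit of > 6 h in this assay, at which 3 of the 3 values shown sit. The compounds shown leave open what the actual half-life of each one is, and whether the two groups differ at all.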